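The source may hold more compounds than are shown below. What is called first, only, known or untested is meant among the compounds shown, and "the series" means these compounds.

In a functional assay on the whole organism (strain Wistar) for inhibition, with Rattus norvegicus as the target, read by paw edema, with stated times of 30 min and 5 h, at a dose of 0.05 mmol/kg by the oral route (a lower number here means less inhibition, a higher number more inhibition at the dose given (going by the name of the read-out)), compound 1 `COc1ccc(C2=NN(c3ccc(S(C)(=O)=O)cc3)C(=O)CC2)cc1` gives 68.4% while compound 2 `CS(=O)(=O)c1ccc(N2N=C(c3ccc(Cl)c(Cl)c3)CCC2=O)cc1` gives 34.2%, the lower of the two numbers. Within the data shown here, the single measured step, a number 34.2 percentage points lower from compound 1 to compound 2 (beyond the scatter), shows that swapping 4-methoxyphenyl for 3,4-dichlorophenyl cost a large share of the inhibition. Compound 3 `CS(=O)(=O)c1ccc(N2N=C(c3ccc(O)c(Cl)c3)CCC2=O)cc1` is not yet measured; it differs from compound 2 by hydroxy in place of chloro on an aromatic carbon, so the 3,4-dichlorophenyl becomes 3-chloro-4-hydroxyphenyl, carrying an oxygen-bearing group para to a large group as compound 1 does, though a hydroxy rather than a methoxy, with one chloro still in place. Among the measured compounds shown here, only the step from compound 1 to compound 2 bears on this, and it points the other way, so a partial return toward compound 1 seems plausible. Compound 3 is therefore expected to show a number 15.8 percentage points higher from compound 2 to compound 3 (beyond the scatter) in this assay, with an estimated inhibition of 50% and a likely range from 30% to 70%.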

Compound 3, a percentage reported as inhibition, in the whole organism at one dose (the size of the read-out at that dose, not a potency): 55.2%
The estimate for compound 3 lay 5.2 percentage points below the measured number; the range from low to high includes it.
By their numbers in this assay, from the lowest: compound 2; then compound 3; then compound 1.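

In this assay, hydroxy in place of chloro gives a number 21 percentage points higher from compound 2 to compound 3 (beyond the scatter), so a change at this one ring position, para to a large group, restores part of the inhibition lost with the 3,4-dichlorophenyl. The recovery is incomplete, as the comparison with the 4-methoxyphenyl gives a number 13.2 percentage points lower from compound 1 to compound 3 (beyond the scatter), but that comparison involves both the hydroxy and the remaining chloro, so it cannot separate their contributions. Nothing available explains why hydroxy and chloro differ in this way at this position.

The compounds shown leave open whether the remaining chloro helps, harms or makes no difference to inhibition. They also do not show how an amine or a carboxylic acid on this same aromatic carbon would compare with hydroxy.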